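Tertiary amine on the chain of compound 2

The compounds below may be only part of what the source reports. "The series", "measured", "known", "first", "only" and "open" are said of these compounds alone.

The series shares the core of compound 1 `CNc1nn2c(N)cc(C)nc2c1S(=O)(=O)c1ccccc1`, which in a functional assay on HEK293 cells for inhibition of 5-hydroxytryptamine receptor 6 (Homo sapiens), read by cAMP accumulation (on this read-out higher numbers stand for weaker inhibition and lower numbers for stronger inhibition), gives 0.302 nM. Compound 2 `CNc1nn2c(CN)cc(C)nc2c1S(=O)(=O)c1ccccc1` carries an aminomethyl where compound 1 has an amino group, and in this assay compound 2 gives 1.86 nM, the highest of the two numbers recorded; the step of a 6.2-fold higher number from compound 1 to compound 2 (0.79 log units; beyond the scatter) is the only one available. Compound 3 `CNc1nn2c(CN(C)C)cc(C)nc2c1S(=O)(=O)c1ccccc1` differs from compound 2 by dimethylamino in place of amino on a saturated chain carbon bound to an aromatic carbon. For the measured compounds named here, no measured step alters this chain-bound amine, so the one known step bears on the change only loosely: it shows that adding to this part of the core weakened inhibition modestly. A further modest weakening, or no step beyond the scatter, is therefore expected, and compound 3 is estimated to show a 1.9-fold higher number from compound 2 to compound 3 (0.27 log units; within the scatter). For compound 3 the expected number is 3.5 nM, in the range 0.9 nM to 14 nM.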

Compound 3, inhibition constant: 1.82 nM
The estimate for compound 3 lay 1.9-fold (0.28 log units) above the measured number, within the range that was stated.
By their numbers in this assay, from the lowest: compound 1; then compounds 3 and 2 (each within the scatter of the next).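

In this assay, dimethylamino in place of amino on a saturated chain carbon bound to an aromatic carbon gives a 1.0-fold lower number from compound 2 to compound 3 (0.01 log units; within the scatter), so at this position, the chain amine tolerates this change, including the loss of its hydrogen-bond donor, with no step beyond the scatter. The distance from the core of compound 1 stays much the same, at a 6.0-fold higher number from compound 1 to compound 3 (0.78 log units; beyond the scatter) against a 6.2-fold higher number from compound 1 to compound 2 (0.79 log units; beyond the scatter), whether the chain amine is primary or tertiary. No measured evidence here explains either result.

The compounds shown leave open whether a bulkier group on this chain nitrogen, such as piperidine or morpholine, would also stay within the scatter of compound 2. They also leave open how dimethylamino set directly on the aromatic carbon, or a longer chain, would compare.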